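The source may report more compounds than this note shows. Statements on the series, on what has been measured and on what is new or still open speak of the compounds shown alone.

Measured compounds:
compound 1 `C=C1CC[C@H]2C(C)(C)CCC[C@]2(C)[C@H]1C/C=C1/C(=O)OC[C@H]1O`: 82.7%
compound 2 `C=C1CC[C@H]2C(C)(C)CCC[C@]2(C)[C@H]1C[C@@H](O)C1=CCOC1=O`: 108%
compound 3 `C=C1CC[C@H]2C(C)(C)CCC[C@]2(C)[C@H]1C/C=C1\CC(O)OC1=O`: 86.3%

In an ADME assay on RAW264.7 cells (Mus musculus) for cytotoxicity, read by luminescence and CellTiter-Glo, with a stated time of 18 h, tested at 5 uM (on this read-out lower numbers stand for a stronger effect and higher numbers for a weaker effect at the one concentration tested), compound 3 gives 86.3%, the second highest of the three numbers. Compound 1 gives 82.7%, a number within the scatter of compound 3. Compound 2 gives 108%, a number beyond the scatter above compound 3.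

Compound 4 `C=C1CC[C@H]2C(C)(C)CCC[C@]2(C)[C@H]1C/C=C1\CC(OC)OC1=O` has not yet been measured. It differs from compound 3 in one place: methyl in place of hydrogen on an oxygen on a saturated carbon. Among the measured compounds shown here, no measured pair shows this kind of change, so nothing in the data sets the size of the step. The step from compound 3 to compound 4 is expected to be small, a number 1.7 percentage points higher from compound 3 to compound 4 (within the scatter), not beyond the scatter in either direction. Compound 4 is therefore expected to give about 88%, with a likely range from 70% to 108%.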

Compound 4, a percentage reported as activity, at one concentration (the size of the read-out at that concentration, not a potency): 101%
For compound 4 the middle estimate is 13 percentage points below the measured one; the range from low to high includes it.
By their numbers in this assay, from the lowest: compounds 1 and 3 (each within the scatter of the next); then compounds 4 and 2 (each within the scatter of the next).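

In this assay, among the compounds shown here, the change from hydroxy to methoxy on this saturated carbon gives a number 14.7 percentage points higher from compound 3 to compound 4 (beyond the scatter), the first single change here that can be read, and it points to a weaker effect at the one concentration tested. Swapping the hydrogen on this oxygen for methyl is therefore not a silent change in this assay. Nothing available here accounts for the shift.

As far as these compounds go, whether a longer chain on this oxygen, such as ethoxy, or an amine in place of the hydroxy would move the number the same way remains open. So does whether methoxy in place of hydroxy would give a similar step on compound 1 or compound 2.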